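The compounds below may be only part of what the source reports. "The series", "measured", "known", "first", "only" and "open" are said of these compounds alone.

Series notes. Compound 1 `COc1ccc(CNC(=O)c2nc(Br)c3cccnc3c2N[C@H]2CC[C@H](N)CC2)cc1` has been assessed in a functional assay on SK-BR-3 cells (Homo sapiens) for cytotoxicity, read by MTT assay, with a stated time of 72 h (a higher number here means a weaker inhibitor, a lower number a stronger inhibitor), where compound 1 gives 5000 nM. Compound 2 `O=C(NCCCNc1c(C(=O)NCc2ccc(F)cc2)nc(Br)c2cccnc12)c1ccccc1`, run in the same way, gives 1000 nM in this assay. Of the two numbers on hand, compound 1 stands highest; its nearest neighbour is compound 2, whose number is lower by a margin beyond the usual scatter. Compound 1 and compound 2 differ in several places at once, so their gap cannot be tied to any single change.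

Compound 3 `N[C@H]1CC[C@H](Nc2c(C(=O)NCc3ccccc3)nc(Br)c3cccnc23)CC1` has not yet been measured. Relative to compound 1 the difference is hydrogen in place of methoxy on an aromatic carbon. Going by the values given here, no pair of measured compounds isolates this change, so there is no measured step to lean on. In this assay the expected outcome is a step of modest size at most, with no firm direction, most likely inside the scatter. The step expected from a 1.3-fold lower number from compound 1 to compound 3 (0.10 log units; within the scatter) is accordingly small. Compound 3 is estimated at 4000 nM, with a range from 1500 nM to 12000 nM.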

Compound 3, half-maximal inhibitory concentration: 8000 nM
Compound 3: middle estimate off by 2.0-fold (0.30 log units), on the low side, within the range that was stated.
By their numbers in this assay, from the lowest: compound 2; then compounds 1 and 3 (each within the scatter of the next).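

Going by these compounds alone, replacing 4-methoxybenzyl by benzyl, with the rest of compound 1 kept, gives in this assay a 1.6-fold higher number from compound 1 to compound 3 (0.20 log units; within the scatter), the first measured step that isolates a single change. At this aromatic carbon, para to a large group, the departure of methoxy, with its 2 heavy atoms and 1 hydrogen-bond acceptor, therefore leaves the cytotoxicity read-out unmoved beyond the scatter, and in this one pair hydrogen and methoxy cannot be told apart. No measurement at hand bears on why the step is this small.

From the compounds shown here alone, whether this place stays as undemanding for other groups remains open: an amine, a carboxylic acid or a longer alkoxy chain such as butoxy could still move the number beyond the scatter, and a single pair says nothing about them. Within the data shown here, also open is whether hydrogen in place of methoxy reads the same with a different side chain on the shared core, such as the one carried by compound 2, since this change has been isolated on the background of compound 1 alone.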